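This account rests on a few compounds, and the source may have more. Where it says the series, first, only, none or still open, it means among the compounds named here.

Measured compounds:
Compound 1 `CSCC[C@H](NC1=CC(=O)C=C(C[C@]2(C)[C@@H](C)CC[C@]3(C)C(C)=CCC[C@@H]23)C1=O)C(=O)O`: in an ADME assay on MRC5 cells (Homo sapiens) for cytotoxicity, read by MTT assay, with a stated time of 72 h (on this read-out higher numbers stand for weaker inhibition and lower numbers for stronger inhibition), compound 1 is reported only as a limit, > 200000 nM.
Compound 2 `CC1=CCC[C@H]2[C@](C)(CC3=CC(=O)C=C(N[C@@H](C)C(=O)O)C3=O)[C@@H](C)CC[C@]12C`: in this assay compound 2 gives 157000 nM.
Compound 3 `C[C@H](NC1=CC(=O)C=C(C(C)(C)C)C1=O)C(=O)O`: in this assay compound 3 is likewise reported only as a limit, > 200000 nM.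
Compound 4 `CSCC[C@H](NC1=CC(=O)C=C(C(C)(C)C)C1=O)C(=O)O`: not yet measured in this assay.

Compound 1 and compound 2 share a core and differ in one place: (methylsulfanyl)methyl in place of hydrogen on a saturated chain carbon, two bonds along the chain from an amine nitrogen and a carbonyl carbon. The step of an at least 1.2-fold higher number from compound 2 to compound 1 (0.10 log units; that floor lies within the scatter) can only be bounded, since compound 1 sits at the limit of > 200000 nM in this assay, at which 2 of the 3 values shown sit. The difference between the core of compound 2 and the core of compound 3 is not broken down here. Compound 4 differs from compound 3 by (methylsulfanyl)methyl in place of hydrogen on a saturated chain carbon, two bonds along the chain from an amine nitrogen and a carbonyl carbon, which is the same change as that seen between compound 2 and compound 1, at the same place.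

Compound 3 is itself already at the limit of > 200000 nM in this assay, at which 2 of the 3 values shown sit. Given that the earlier step did not bring its compound below that limit, the step is expected to be about a step that the limit leaves unreadable from compound 3 to compound 4. Compound 4 is therefore expected at 250000 nM, with a range from 120000 nM to 600000 nM, and most probably it will again be reported only as a limit in this assay.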

Compound 4, half-maximal inhibitory concentration: > 200000 nM
Compound 4: a limit, no number (the forecaster's own chance of this, stated with the estimate: 80%); the middle value does not contradict the limit.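

In this assay compound 4, like compound 3, is reported only as a limit, so no step can be read between these two compounds: the limit of > 200000 nM in this assay, at which 3 of the 4 values shown sit.

The compounds shown leave open how far past that limit compound 1, compound 3 and compound 4 lie, and so whether (methylsulfanyl)methyl in place of hydrogen has any readable size on either core.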